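This account rests on a few compounds, and the source may have more. Where it says the series, first, only, none or still open, it means among the compounds named here.

Measured compounds:
compound 1, `Cn1ncnc1-c1ccccc1NCC1=NCCN1`: 63.1 nM
compound 2, `CCCn1ncnc1-c1ccccc1NCC1=NCCN1`: 251 nM
compound 3, `CC(C)n1ncnc1-c1ccccc1NCC1=NCCN1`: 3160 nM

Among these three, compound 1 gives the lowest number in an in vitro functional assay on cells (Fibroblast) for agonist activity at Alpha-1D adrenergic receptor (Homo sapiens); on this read-out higher numbers stand for an effect only at larger amounts of compound and lower numbers for an effect already at smaller amounts. The step of a 4.0-fold higher number from compound 1 to compound 2 (0.60 log units; beyond the scatter) is modest, while the step of a 50-fold higher number from compound 1 to compound 3 (1.70 log units; beyond the scatter) is large, so compound 1 stands clearly apart from both other measured compounds. Compound 4, `c1ccc(-c2cn[nH]c2)c(NCC2=NCCN2)c1`, has not yet been measured. It differs from compound 1 in this way: 1H-pyrazol-4-yl in place of 1-methyl-1H-1,2,4-triazol-5-yl on an aromatic carbon. Among the measured compounds shown here, none of the measured steps exchanges the whole five-membered ring; each only alters the group on the aromatic nitrogen, as in a 13-fold higher number from compound 2 to compound 3 (1.10 log units; beyond the scatter), and those steps show that every alteration made so far in this part of the molecule raised the number, by a modest to large amount. Because compound 1 gives 63.1 nM and all measured departures from it went upward, a rise of uncertain size is expected for compound 4, a 3.2-fold higher number from compound 1 to compound 4 (0.50 log units; beyond the scatter), though the exchange of the entire ring makes this expectation loose. Compound 4 is therefore estimated to give 200 nM, with a likely range from 25 nM to 1600 nM.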

Compound 4, half-maximal effective concentration: 20 nM
For compound 4 the middle estimate is 10-fold (1.00 log units) above the measured one, and the stated range ends above it.
By their numbers in this assay, from the lowest: compound 4; then compound 1; then compound 2; then compound 3.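

In this assay, exchanging the whole five-membered ring on this aromatic carbon gives a 3.2-fold lower number from compound 1 to compound 4 (0.50 log units; beyond the scatter), the only downward step among the compounds shown, whereas all the steps that alter the group on the aromatic nitrogen go upward. The position therefore accepts a different ring, and the 1H-pyrazol-4-yl group, with one hydrogen-bond donor where the 1-methyl-1H-1,2,4-triazol-5-yl group has none, gives the lowest number of the four compounds. No measurement shown here bears on why the number fell.

This single exchange changes the ring, its hetero atoms, its point of attachment and the hydrogen on nitrogen together, and the compounds shown do not separate these changes. As far as these compounds go, it remains open whether a methyl on the pyrazole nitrogen would keep the lower number, or whether a 1H-1,2,4-triazolyl or imidazolyl ring would do the same.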